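Replacing the dichlorophenyl of compound 1 with a chlorofluorophenyl

The compounds below may be only part of what the source reports. "The series", "measured", "known", "first", "only" and "open" are said of these compounds alone.

Measured compounds:
compound 1, `CN(C)CCn1cnnc1-c1cc(Oc2ccc(NC(=O)N/N=C/c3c(Cl)cccc3Cl)cc2F)ccn1`, 350 nM
compound 2, `COc1ccc(/C=N/NC(=O)Nc2ccc(Oc3ccnc(-c4nncn4CCN(C)C)c3)c(F)c2)c(OC)c1OC`, 1790 nM
compound 3, `CN(C)CCn1cnnc1-c1cc(Oc2ccc(NC(=O)N/N=C/c3ccccc3)cc2F)ccn1`, 1780 nM

In a functional assay on NCI-H460 cells (Homo sapiens) for cytotoxicity, read by MTT assay, with a stated time of 72 h (on this read-out higher numbers stand for weaker inhibition and lower numbers for stronger inhibition), compound 1 gives the lowest number of the three. Compound 3 carries a phenyl where compound 1 has the 2,6-dichlorophenyl, and compound 2 a 2,3,4-trimethoxyphenyl; the steps of a 5.1-fold higher number from compound 1 to compound 3 (0.71 log units; beyond the scatter) and a 5.1-fold higher number from compound 1 to compound 2 (0.71 log units; beyond the scatter) are alike in size and direction, while a 1.0-fold lower number from compound 2 to compound 3 (0.00 log units; within the scatter) shows no separation between those two. Compound 4, `CN(C)CCn1cnnc1-c1cc(Oc2ccc(NC(=O)N/N=C/c3ccc(F)cc3Cl)cc2F)ccn1`, is the same core with a change at the same position: 2-chloro-4-fluorophenyl in place of 2,6-dichlorophenyl on a carbon with a double bond to nitrogen. The entering group keeps one chlorine of the two that leave and adds a fluorine, so it sits between the 2,6-dichlorophenyl of compound 1 and the phenyl of compound 3 in the sense of what is present on the ring. The two measured steps from compound 1 both went toward weaker inhibition, so a step in that direction is expected for compound 4, but a smaller one, because a 5.1-fold higher number from compound 1 to compound 3 (0.71 log units; beyond the scatter) removed both chlorines while the entering group keeps one of them. Compound 4 is estimated at 750 nM, with a range of 300 nM to 1900 nM, meaning an expected step of a 2.1-fold higher number from compound 1 to compound 4 (0.33 log units; beyond the scatter).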

Compound 4, half-maximal inhibitory concentration: 720 nM
Compound 4: the middle estimate sits 1.0-fold (0.02 log units) above what was measured; the measured number falls inside the stated range.
By their numbers in this assay, from the lowest: compound 1; then compound 4; then compounds 3 and 2 (each within the scatter of the next).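

In this assay, the ring on the carbon with a double bond to nitrogen no longer gives only two levels, as compound 4 stands apart from both sides. It loses ground against the 2,6-dichlorophenyl (a 2.1-fold higher number from compound 1 to compound 4 (0.31 log units; beyond the scatter)), yet stays clear of the phenyl (a 2.5-fold lower number from compound 3 to compound 4 (0.39 log units; beyond the scatter)) and of the 2,3,4-trimethoxyphenyl (a 2.5-fold lower number from compound 2 to compound 4 (0.40 log units; beyond the scatter)). No measurement at hand explains these differences.

Since the 2-chloro-4-fluorophenyl differs from the phenyl by both a chlorine and a fluorine, the compounds shown do not separate what each contributes. They also leave open where a 2-chlorophenyl, a 2,6-difluorophenyl or a ring bearing a nitrile or an amine would fall in this order.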